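This account rests on a few compounds, and the source may have more. Where it says the series, first, only, none or still open, it means among the compounds named here.

In a functional assay on U2OS cells (Homo sapiens) for cytotoxicity, read by MTT assay, with a stated time of 48 h (on this read-out lower numbers stand for stronger inhibition and higher numbers for weaker inhibition), compound 1 `Fc1ccc2nc(-c3ccccc3)nc(Nc3ccccc3)c2c1` gives > 50000 nM, which is a limit of the assay rather than a number. Compound 2 `Fc1ccc(Nc2nc(-c3cccc(F)c3)nc3ccc(F)cc23)cc1` likewise gives only a limit, > 50000 nM. Within the data shown here, compound 3 `Fc1cccc(Nc2nc(-c3cccc(F)c3)nc3ccc(F)cc23)c1` is the single compound with a measured number, 49600 nM, and it stands alone there, since the limit of > 50000 nM in this assay, at which 2 of the 3 values shown sit, covers the other two. Among the measured compounds shown here, the one measured step, a number no higher from compound 2 to compound 3 (the limit leaves the size open), leaves its size open. Compound 4 `Fc1cccc(-c2nc(Nc3ccc(Br)cc3)c3cc(F)ccc3n2)c1` differs from compound 3 by 4-bromophenyl in place of 3-fluorophenyl on a nitrogen on an aromatic ring. For the measured compounds named here, no measured step reads a size at this place, so no direction beyond the scatter can be expected in this assay. Compound 4 is therefore estimated at 50000 nM, between 20000 nM and 120000 nM. The expected step is a 1.0-fold higher number from compound 3 to compound 4 (0.00 log units; within the scatter), within the scatter.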

Compound 4, half-maximal inhibitory concentration: > 50000 nM
Compound 4: no number, only a limit; the forecaster's own chance of this, stated with the estimate: 55%; the middle value sits exactly at the limit.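

Replacing 3-fluorophenyl with 4-bromophenyl on the nitrogen gives, in this assay, a number no lower from compound 3 to compound 4 (the limit leaves the size open). Compound 4 gives only a limit, so the step between compound 2 and compound 4, bromo in place of fluoro, cannot be read. Compound 3 remains the only compound with a measured number, and the others sit at one ceiling: the limit of > 50000 nM in this assay, at which 3 of the 4 values shown sit.

The compounds shown leave open whether any group on this ring brings the number clear of that limit. A carboxylic acid or an aminomethyl group in place of the halogen would test this.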